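This account rests on a few compounds, and the source may have more. Where it says the series, first, only, none or still open, it means among the compounds named here.

Compound 1 `Cc1cc(C)cc(C(=O)N(CC(=O)NCc2ccccc2)Cc2ccc(C(=O)Nc3cc(-c4ccccc4)ccc3N)cc2)c1` is the starting point of this short series. In an assay on Sf9 cells for inhibition of protein deacetylase HDAC6 (Homo sapiens), read by fluorescence, with a stated time of 90 min (a lower number here means a stronger inhibitor, a higher number a weaker inhibitor), compound 1 gives > 10000 nM, which is a limit of the assay rather than a measured number. Its two companions sit in the same place. Compound 2 `CN(C)c1ccc(C(=O)N(CCCCCC(=O)Nc2cc(F)ccc2N)CC(=O)NCc2ccccc2)cc1` gives > 10000 nM in this assay, again a limit. Compound 3 `Cc1cc(C)cc(C(=O)N(CCCCCC(=O)Nc2ccccc2N)CC(=O)NCc2ccccc2)c1` gives > 10000 nM in this assay, also a limit. Every value shown here thus rests at the limit of > 10000 nM in this assay, at which 3 of the 3 values shown sit, so compound 1 stands nowhere in particular among them: none of the three carries a number that could be ranked against the others.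

Compound 4 `Cc1cc(C)cc(C(=O)N(CC(=O)NCc2ccccc2)Cc2ccc(C(=O)Nc3ccccc3N)cc2)c1` differs from compound 1 in one place: hydrogen in place of phenyl on an aromatic carbon. Within the data shown here, no measured pair shows what such a change does in this assay. With all three measured compounds at the limit, the expected change is none beyond the scatter, and the step is estimated as a step that the limit leaves unreadable from compound 1 to compound 4. Compound 4 is therefore expected to give about 15000 nM in this assay, most likely reported only as a limit, within a range from 4000 nM to 60000 nM.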

Compound 4, half-maximal inhibitory concentration: > 10000 nM
Compound 4 ended at the assay's limit; the forecaster's own chance of this, stated with the estimate: 85%; the middle value is on the limit's open side.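

In this assay compound 4 gives > 10000 nM, a limit rather than a number. Compound 1 also rests at a limit, so no step from it to compound 4 can be read: the limit of > 10000 nM in this assay, at which 4 of the 4 values shown sit.

The compounds shown leave open how strongly any of them acts in this assay, and whether hydrogen in place of phenyl changes that at all.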